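The source may report more compounds than this note shows. Statements on the series, on what has been measured and on what is new or still open speak of the compounds shown alone.

Measured so far in a functional assay on K562 cells (Homo sapiens) for cytotoxicity, read by MTT assay; on this read-out higher numbers stand for weaker inhibition and lower numbers for stronger inhibition:
compound 1 `C/C=C(/C)C(=O)O[C@@H]1C/C=C(\C)CCCC(C)(C)[C@@H](O)/C=C\1C`, "not active" (no number reported)
compound 2 `C/C=C(/C)C(=O)O[C@@H]1C/C=C(\C)CCCC(C)(C)[C@@H](OC(C)=O)/C=C\1C`, > 50000 nM
compound 3 `C/C1=C/[C@H](O)C(C)(C)CCC/C(C)=C/C[C@H]1OC(=O)c1ccc(O)cc1`, > 50000 nM

In this assay compound 2 gives only a limit, > 50000 nM, not a number. Compound 3 likewise sits at a limit in this assay, > 50000 nM. Compound 1 is recorded as "not active" (no number reported), with no number at all. Going by the values given here, compound 2 therefore stands at the limit of > 50000 nM in this assay, at which 2 of the 3 values shown sit, and no measured compound lies anywhere below it. Compound 4 `CC(=O)O[C@H]1/C=C(/C)[C@H](OC(=O)c2ccc(O)cc2)C/C=C(\C)CCCC1(C)C` has not been measured. It differs from compound 2 in one place: 4-hydroxyphenyl in place of 1-methylprop-1-en-1-yl on a carbonyl carbon. Compound 3 carries the same 4-hydroxyphenyl group on its carbonyl carbon and still reaches only a limit. Among the compounds with values here, no step between measured compounds is known, so the change is expected to bring no shift beyond the scatter, an expected step that the limit leaves unreadable from compound 2 to compound 4. Compound 4 is expected to give about 80000 nM in this assay, between 30000 nM and 300000 nM, most likely reported again only as a limit.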

Compound 4, half-maximal inhibitory concentration: 33000 nM
Compound 4: the middle estimate sits 2.4-fold (0.38 log units) above what was measured, within the range that was stated.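

In this assay, compound 4 is the first compound shown to give a number rather than a limit, so the pairing of 4-hydroxyphenyl on the carbonyl carbon with the acetyl group can finally be read. Exchanging the carbonyl substituent gives an at least 1.5-fold lower number from compound 2 to compound 4 (0.18 log units; that floor lies within the scatter), and adding acetyl on the oxygen gives an at least 1.5-fold lower number from compound 3 to compound 4 (0.18 log units; that floor lies within the scatter). Neither floor establishes a real change, and the comparison values remain limits: the limit of > 50000 nM in this assay, at which 2 of the 4 values shown sit.

Still open, on these data alone, is whether a group carrying an amine or a carboxylic acid on that carbonyl carbon would move the number clearly beyond the scatter.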